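A few compounds are considered here, and "the series" means these few. Any claim that something is new, unique, unknown or untested is made for them only; others in the source may bear on it.

Compound 1 `Nc1cc(N)c2nc(-c3ccccc3)c(Oc3ccc(Cl)c(Cl)c3)nc2c1` gives 30900 nM in a functional assay on SF-295 cells (Homo sapiens) for inhibition, read by sulforhodamine B assay, with a stated time of 48 h; a higher number here means a weaker inhibitor of growth, a lower number a stronger inhibitor of growth. Compound 2 `Nc1cc(N)c2nc(-c3ccccc3)c(NCc3ccc(Cl)c(Cl)c3)nc2c1` gives 37200 nM in this assay. Compound 3 `COc1ccc(CNc2nc3cc(N)cc(N)c3nc2-c2ccccc2)cc1OC` gives 28200 nM in this assay, the lowest of the three numbers, though its gaps to compound 1 and to compound 2 both lie within the scatter. Compound 4 `COc1cc(CNc2nc3cc(N)cc(N)c3nc2-c2ccccc2)cc(OC)c1OC` has not yet been measured; it differs from compound 3 by methoxy in place of hydrogen on an aromatic carbon. For the measured compounds named here, the one measured step that touches this part of the structure, a 1.3-fold lower number from compound 2 to compound 3 (0.12 log units; within the scatter), exchanged the entire substituted ring and still stayed within the scatter, so one further methoxy is expected to shift the number no more than that. Compound 4 is therefore estimated at 28000 nM, between 14000 nM and 56000 nM, an expected step of a 1.0-fold lower number from compound 3 to compound 4 (0.00 log units; within the scatter) in this assay.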

Compound 4, concentration for total growth inhibition: 5620 nM
Estimate against measurement, compound 4: 5.0-fold (0.70 log units) above; measured number below the stated range.
By their numbers in this assay, from the lowest: compound 4; then compounds 3, 1 and 2 (each within the scatter of the next).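

In this assay the added methoxy gives a 5.0-fold lower number from compound 3 to compound 4 (0.70 log units; beyond the scatter), the first step among these compounds that lies beyond the scatter. This aromatic carbon, ortho to a methoxy group, therefore responds to one small substituent, whereas exchanging the whole substituted ring gave only a 1.3-fold lower number from compound 2 to compound 3 (0.12 log units; within the scatter). No measurement at hand bears on the reason for this difference. The compounds shown leave open whether a hydroxy, an ethoxy or a fluorine on this carbon would give a step of similar size. They also leave open whether a single methoxy here, without its two neighbouring methoxy groups, would do the same.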